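This account rests on a few compounds, and the source may have more. Where it says the series, first, only, none or still open, it means among the compounds named here.

Measured compounds:
- compound 1 `CCN(Cc1ccc(C)s1)C(=O)COc1ccc(C)cc1`: 178 nM
- compound 2 `Cc1ccc(OCC(=O)N(Cc2cccs2)C2CCCCC2)cc1`: 40000 nM
- compound 3 `CCN(Cc1cccs1)C(=O)COc1ccc(Cl)cc1`: 39 nM

The three measured compounds were run in an assay on HEK293 cells for agonist activity at transient receptor potential cation channel subfamily M member 8 (Homo sapiens), read by fluorescence and calcium flux, with a stated time of 15 min; a lower number here means that less compound is needed, a higher number that more compound is needed for the effect. Compound 2 stands at the high end of the three numbers, with 40000 nM; the nearest value is that of compound 1, and the furthest that of compound 3, both gaps lying beyond the scatter. No pair of these compounds differs in a single place, so no step between measured compounds can be read off; compound 1 and compound 3 both carry a small chain on the amide-type nitrogen, while compound 2 carries a cyclohexyl there, and that is where the next compound departs from compound 2.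

Compound 4 `Cc1ccc(OCC(=O)N(Cc2cccs2)c2ccncc2)cc1` has not yet been measured in this assay. Its difference from compound 2: pyridin-4-yl in place of cyclohexyl on an amide-type nitrogen. The change keeps the ring size but brings in an aromatic ring with one hetero atom and one hydrogen-bond acceptor. With no measured step of this kind in the series, the direction is open; the expectation leans toward a modest move down from compound 2, since both other measured compounds with a smaller substituent on that nitrogen give lower numbers, but the range is wide.

The step from compound 2 to compound 4 is estimated as a 2.7-fold lower number from compound 2 to compound 4 (0.43 log units; beyond the scatter). For compound 4 the expected value is 15000 nM, with a range from 2500 nM to 60000 nM.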

Compound 4, half-maximal effective concentration: 52 nM
Compound 4: the middle estimate sits 290-fold (2.46 log units) above what was measured; measured number below the stated range.
By their numbers in this assay, from the lowest: compounds 3 and 4 (each within the scatter of the next); then compound 1; then compound 2.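

In this assay, among the compounds shown here, pyridin-4-yl in place of cyclohexyl on the amide-type nitrogen gives a 770-fold lower number from compound 2 to compound 4 (2.89 log units; beyond the scatter) as the first single-place step, and it is a large one. The number at this position is therefore highly sensitive to the identity of the ring, even though both groups are six-membered rings and the heavy-atom count stays the same; what changes is an aromatic ring with one hetero atom and one hydrogen-bond acceptor in place of a non-aromatic ring of carbon only. No measured evidence explains the size of this step.

This single pair cannot separate the contribution of aromaticity from that of the ring nitrogen, and phenyl on the same amide-type nitrogen, with the rest of compound 2 unchanged, would divide the two. Pyridin-3-yl and pyridin-2-yl would test whether the placement of the ring nitrogen matters, while an ethyl group on that nitrogen, again with the rest of compound 2 unchanged, would show how an open chain compares with both rings.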